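Series notes: benzyl to methylsulfonyl on the aryl oxygen

The source may hold more compounds than are shown below. What is called first, only, known or untested is meant among the compounds shown, and "the series" means these compounds.

The shared core is seen in compound 1 `COC(=O)/C=C/c1cccc(N(Cc2ccc(-c3ccc(F)c(Cl)c3)cc2)C(=O)C2CCCCC2)c1`, which in an assay on isolated protein with Bile acid receptor (Homo sapiens) as the target (on this read-out lower numbers stand for an effect already at smaller amounts and higher numbers for an effect only at larger amounts of compound), gives 66 nM. Compound 2 `COC(=O)/C=C/c1cccc(N(Cc2ccc(C(C)(C)C)cc2)C(=O)C2CCCCC2)c1` carries tert-butyl in place of 3-chloro-4-fluorophenyl; in this assay compound 2 gives > 1000 nM, a limit of the assay and not a number. Within the data shown here, the step of an at least 15-fold higher number from compound 1 to compound 2 (1.18 log units; beyond the scatter) is the only measured step with a number at one end. Compound 3 `COC(=O)/C=C/c1cccc(N(Cc2ccc(/C=C/C(=O)OC(C)(C)C)cc2OCc2ccccc2)C(=O)C2CCCCC2)c1` carries a different arm on the benzyl group. In this assay compound 3 gives > 1000 nM, again a limit of the assay. Compound 3 thus stands at the limit of > 1000 nM in this assay, at which 2 of the 3 values shown sit, with no number to move from. Compound 4 `COC(=O)/C=C/c1cccc(N(Cc2ccc(/C=C/C(=O)OC(C)(C)C)cc2OS(C)(=O)=O)C(=O)C2CCCCC2)c1` differs from compound 3 in one place: methylsulfonyl in place of benzyl on an oxygen on an aromatic ring. Among the measured compounds shown here, no measured step touches this oxygen, and the one measured step, at a different position, runs out of the numbered range. For compound 4 the expected step is a step that the limit leaves unreadable from compound 3 to compound 4, which against a limit cannot be resolved, a further limit being the likely outcome. Compound 4 is estimated at 2000 nM, within 500 nM to 10000 nM.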

Compound 4, half-maximal effective concentration: > 1000 nM
Compound 4 gave a limit, no number; the forecaster's own chance of this, stated with the estimate: 70%; the middle value does not contradict the limit.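

Compound 3 and compound 4 both sit at a limit of the assay and give no number, so no step can be read between them: the limit of > 1000 nM in this assay, at which 3 of the 4 values shown sit.

The compounds shown leave open whether methylsulfonyl in place of benzyl on an oxygen on an aromatic ring changes the read-out at all.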